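The source may report more compounds than this note shows. Statements on the series, on what has been measured and on what is new or still open speak of the compounds shown alone.

Measured compounds in a functional assay on A375P cells (Homo sapiens) for cytotoxicity, read by MTT assay; on this read-out higher numbers stand for weaker inhibition and lower numbers for stronger inhibition:
- compound 1 `COC(=O)c1ccc2c(ccn2-c2cccc(NC(=O)Nc3ccc(Cl)c(C(F)(F)F)c3)c2)n1`, compound 1 gives 9500 nM
- compound 2 `O=C(Nc1ccc(-n2ccc3nc(C(=O)NCc4ccccc4)ccc32)cc1)c1ccc(Cl)c(C(F)(F)F)c1`, compound 2 gives 700 nM
- compound 3 `COC(=O)c1ccc2c(ccn2-c2ccc(NC(=O)Nc3ccc(Cl)c(Cl)c3)cc2)n1`, compound 3 gives 3800 nM

Compound 3 sits second highest of the three numbers. Its nearest neighbour is compound 1, whose number is higher by a gap beyond the scatter; compound 2 lies furthest away, with a number lower by a gap well beyond the scatter. Going by the values given here, no single-change pair among the measured compounds exists, so no measured step can be read off; compounds 1 and 3 differ in more than one place and only their two values can be set side by side.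

Compound 4 `NC(=O)c1ccc2c(ccn2-c2ccc(NC(=O)Nc3ccc(Cl)c(Cl)c3)cc2)n1` is the next compound to be measured in this assay. It differs from compound 3 in one place: amino in place of methoxy on a carbonyl carbon

Nothing in the measured set shows what this change does here. The expected step from compound 3 to compound 4, a 1.1-fold lower number from compound 3 to compound 4 (0.04 log units; within the scatter), is small and within the scatter, with no clear direction. Compound 4 is therefore estimated at 3500 nM, within a range of 1200 nM to 10000 nM.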

Compound 4, half-maximal inhibitory concentration: 3200 nM
Compound 4: the middle estimate sits 1.1-fold (0.04 log units) above what was measured; the measured number falls inside the stated range.
By their numbers in this assay, from the lowest: compound 2; then compounds 4 and 3 (each within the scatter of the next); then compound 1.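

In this assay the series now has its first single-change step (a 1.2-fold lower number from compound 3 to compound 4 (0.07 log units; within the scatter)), and it shows that methoxycarbonyl and carbamoyl cannot be told apart on this read-out when the rest of the molecule is that of compound 3. On this carbonyl carbon, amino can therefore stand in for methoxy, with one hydrogen-bond donor entering and one hydrogen-bond acceptor leaving, and no shift beyond the scatter follows. No measurement at hand accounts for this result.

Going by these compounds, what a carboxylic acid or a dimethylamino group would give on the same carbonyl carbon remains open. Also open, on these data alone, is whether the exchange of methoxy for amino would give a similar step with the urea substituents and attachment of compound 1.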